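Trifluoromethyl on the benzoyl group of compound 3

This account rests on a few compounds, and the source may have more. Where it says the series, first, only, none or still open, it means among the compounds named here.

Values in a functional assay on K562 cells (Homo sapiens) for cytotoxicity, read by MTT assay, with a stated time of 72 h (on this read-out higher numbers stand for weaker inhibition and lower numbers for stronger inhibition), are as follows:
compound 1 `C=C1C(=O)[C@@]23C(=O)OC[C@]4(C(=O)CCC(C)(C)[C@H]4C=O)[C@@H]2CC[C@@H]1[C@H]3O` gives 2180 nM
compound 2 `C=C1C(=O)[C@@]23C(=O)OC[C@]4([C@@H](OC(C)=O)CCC(C)(C)[C@H]4C=O)[C@@H]2CC[C@@H]1[C@H]3O` gives 9560 nM
compound 3 `C=C1C(=O)[C@@]23C(=O)OC[C@]4(C(=O)CCC(C)(C)[C@H]4C=O)[C@@H]2CC[C@@H]1[C@H]3OC(=O)c1ccccc1` gives 1480 nM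

Compound 3 (1480 nM) sits well under compound 2 (9560 nM), while compound 1 cannot be separated from it on these numbers. The next structure is compound 4 `C=C1C(=O)[C@@]23C(=O)OC[C@]4(C(=O)CCC(C)(C)[C@H]4C=O)[C@@H]2CC[C@@H]1[C@H]3OC(=O)c1ccc(C(F)(F)F)cc1`, which differs from compound 3 only on the aromatic ring: trifluoromethyl in place of hydrogen on an aromatic carbon. This places trifluoromethyl in place of hydrogen on an aromatic carbon, para to a large group. Within the data shown here, no measured step varies a substituent on that ring. Among the measured compounds shown here, the only measured step involving the benzoyl group is a 1.5-fold lower number from compound 1 to compound 3 (0.17 log units; within the scatter), and it adds the whole group yet stays small. No step beyond the scatter is therefore expected in this assay, and neither direction is favoured. Compound 4 is estimated at 1400 nM, with an expected range from 650 nM to 3000 nM for the measurement. The expected step is a 1.1-fold lower number from compound 3 to compound 4 (0.02 log units; within the scatter), an estimate only.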

Compound 4, half-maximal inhibitory concentration: 2820 nM
The estimate for compound 4 lay 2.0-fold (0.30 log units) below the measured number; measured number inside the range.
By their numbers in this assay, from the lowest: compounds 3, 1 and 4 (each within the scatter of the next); then compound 2.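

In this assay, a substituent on the aromatic ring of the benzoyl group can now be read directly: trifluoromethyl in place of hydrogen, para to a large group, gives a 1.9-fold higher number from compound 3 to compound 4 (0.28 log units; within the scatter), so this place on the ring tolerates the group without a step beyond the scatter. Read against the free hydroxyl, (4-(trifluoromethyl)phenyl)carbonyl in place of hydrogen on the oxygen gives a 1.3-fold higher number from compound 1 to compound 4 (0.11 log units; within the scatter), which matches the plain benzoyl result in staying within the scatter. No data on the cause of either step accompany these numbers.

On these data alone, whether an amine or a carboxylic acid on the same ring, or a longer chain in place of the benzoyl group, would give a step beyond the scatter remains open. Also open, as far as these compounds go, is how trifluoromethyl would read at other places on that ring.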